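A few compounds are considered here, and "the series" means these few. Any claim that something is new, unique, unknown or untested is made for them only; others in the source may bear on it.

Compound 2, `O/N=C(\c1cnco1)c1nc2ccccc2s1`, was examined in an ADME assay on CHO cells (Cricetulus griseus) for cytotoxicity; on this read-out lower numbers stand for stronger inhibition and higher numbers for weaker inhibition. In this assay compound 2 gives > 100000 nM, which is a limit of the assay and not a number. Its closest measured neighbour is compound 1, `C/C(=N\O)c1nc2ccccc2s1`, which differs from it only in carrying methyl where compound 2 carries 1,3-oxazol-5-yl on a carbon with a double bond to nitrogen. In this assay compound 1 gives > 100000 nM, again a limit of the assay. The step that the two limits leave unreadable from compound 1 to compound 2 therefore cannot be read in size or direction, since (the limit of > 100000 nM in this assay, at which 2 of the 2 values shown sit). Compound 3, `O/N=C(\c1cnccn1)c1nc2ccccc2s1`, carries pyrazin-2-yl in place of 1,3-oxazol-5-yl on a carbon with a double bond to nitrogen. Within the data shown here, the one measured step that bears on exchanging the group at that carbon is a step that the two limits leave unreadable from compound 1 to compound 2, and it tells nothing about how large such an exchange can be in this assay. With both known values sitting at the limit, compound 3 is expected to sit there as well, with an estimate of 200000 nM and a range from 60000 nM to 700000 nM. The step that the limit leaves unreadable from compound 2 to compound 3 is thus expected to be none beyond the scatter.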

Compound 3, half-maximal inhibitory concentration: 11700 nM
Estimate against measurement, compound 3: 17-fold (1.23 log units) above, outside the stated range (below it).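

In this assay, pyrazin-2-yl in place of 1,3-oxazol-5-yl on a carbon with a double bond to nitrogen gives an at least 8.5-fold lower number from compound 2 to compound 3 (0.93 log units; beyond the scatter), and the same group in place of methyl gives an at least 8.5-fold lower number from compound 1 to compound 3 (0.93 log units; beyond the scatter). The group at this carbon can therefore bring the read-out within the measurable range, something compound 1 and compound 2 could not show, and the two aromatic rings with 2 hetero atoms are not interchangeable here, as the six-membered ring of compound 3 separates from the five-membered ring of compound 2. The full size of both steps cannot be read because the values of compound 1 and compound 2 are limits of the assay: the limit of > 100000 nM in this assay, at which 2 of the 3 values shown sit.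

The compounds shown leave open whether a phenyl or pyridin-2-yl group, or a pyrazin-2-yl ring carrying an amine, would also give a measurable value at this carbon. With a single core shared by all three compounds, they also leave open whether pyrazin-2-yl would give a step of this kind on any other core.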